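Furan-2-yl in Place of 1,3-thiazol-2-yl: Compound 3

The source may hold more compounds than are shown below. What is called first, only, known or untested is meant among the compounds shown, and "the series" means these compounds.

Of the compounds shown here, two built on a shared core have been measured in an assay on isolated protein for inhibition of Amine oxidase [flavin-containing] A (Homo sapiens), read by fluorescence; on this read-out lower numbers stand for stronger inhibition and higher numbers for weaker inhibition. Compound 1, `O=C(/C=C/c1nccs1)c1cc(O)c(O)c([N+](=O)[O-])c1`, gives 69600 nM. Compound 2, `CC(=O)N1N=C(c2cc(O)c(O)c([N+](=O)[O-])c2)CC1c1nccs1`, gives 84600 nM. Compound 1 stands at the lowest of the two numbers, but compound 2 lies within the scatter of it, so the two read as alike rather than as ordered.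

Compound 3, `O=C(/C=C/c1ccco1)c1cc(O)c(O)c([N+](=O)[O-])c1`, has not been measured. It differs from compound 1 in one place: furan-2-yl in place of 1,3-thiazol-2-yl on a double-bonded chain carbon bound to a double-bonded chain carbon. For the measured compounds named here, no pair of measured compounds shows this change, so its effect has to be judged without a precedent. Both measured compounds carry 1,3-thiazol-2-yl and sit close together; nothing among them speaks for a large shift on the switch to furan-2-yl. The step of a 1.0-fold higher number from compound 1 to compound 3 (0.00 log units; within the scatter) is therefore expected to be small, in no particular direction, and to stay within the scatter. Compound 3 is accordingly estimated at 70000 nM in this assay, with a range from 25000 nM to 200000 nM.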

Compound 3, half-maximal inhibitory concentration: 60500 nM
For compound 3 the middle estimate is 1.2-fold (0.06 log units) above the measured one; measured number inside the range.
By their numbers in this assay, from the lowest: compounds 3, 1 and 2 (each within the scatter of the next).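

In this assay, furan-2-yl in place of 1,3-thiazol-2-yl on a double-bonded chain carbon bound to a double-bonded chain carbon gives a 1.2-fold lower number from compound 1 to compound 3 (0.06 log units; within the scatter) and so leaves the number unchanged within the scatter. This first pair at the position shows that, on the core of compound 1, a five-membered aromatic ring with 1 hetero atom reads the same as one with 2 hetero atoms, so the nitrogen and sulfur of the leaving ring are not needed to hold a number of this size. Nothing available gives a reason for this likeness between the two rings.

Whether the same change would read alike on the core of compound 2 remains open, as that core is shown here only with 1,3-thiazol-2-yl. Also open, going by these compounds, is whether a group of another kind at this place, such as a phenyl ring, an amine, a carboxylic acid or a longer chain, would move the number beyond the scatter, as the two five-membered aromatic rings compared here do not.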